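Changing the Group on the Ring Nitrogen

A few compounds are considered here, and "the series" means these few. Any claim that something is new, unique, unknown or untested is made for them only; others in the source may bear on it.

Of the compounds shown here, three sharing one core have been measured in a functional assay on PC-3 cells (Homo sapiens) for inhibition, with a stated time of 72 h; a higher number here means a weaker inhibitor, a lower number a stronger inhibitor. Compound 1 (`CO[C@H]1CC[C@H](CN2C(=O)CNc3ncc(-c4ccc(-c5nc[nH]n5)nc4C)nc32)CC1`) gives 142 nM, and compound 2 (`CO[C@H]1CC[C@@H](CN2C(=O)CNc3ncc(-c4ccc(-c5nc[nH]n5)nc4C)nc32)CC1`) gives 24 nM. The gap is a 5.9-fold lower number from compound 1 to compound 2 (0.77 log units; beyond the scatter), and it goes with the fact that compounds 1 and 2 differ only in the configuration as drawn. Compound 3 (`Cc1nc(-c2nc[nH]n2)ccc1-c1cnc2c(n1)N([C@H]1CC[C@H](O)CC1)C(=O)CN2`) gives 119 nM, which places it level with compound 1 within the scatter and clearly apart from compound 2.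

The next compound, compound 4 (`Cc1nc(-c2nc[nH]n2)ccc1-c1cnc2c(n1)N(CCC1CCOCC1)C(=O)CN2`), carries 2-(oxan-4-yl)ethyl in place of 4-hydroxycyclohexyl on an amide-type nitrogen in a ring.

Two measured steps change the group at this nitrogen: a 1.2-fold lower number from compound 1 to compound 3 (0.08 log units; within the scatter) and a 5.0-fold higher number from compound 2 to compound 3 (0.70 log units; beyond the scatter). The first lies within the scatter and the second beyond it, so the size of such a step depends on the partner compound. Neither step involves 2-(oxan-4-yl)ethyl, so they offer only a rough span for a change at this nitrogen. In this assay, no step beyond the scatter is expected in either direction. The estimated change is a 1.3-fold lower number from compound 3 to compound 4 (0.12 log units; within the scatter). Compound 4 is expected to give about 90 nM, with an estimated range of 28 nM to 280 nM.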

Compound 4, half-maximal inhibitory concentration: 34 nM
Beside the measured number, compound 4's estimate is 2.6-fold (0.42 log units) above it, and the stated range covers the measured number.
By their numbers in this assay, from the lowest: compounds 2 and 4 (each within the scatter of the next); then compounds 3 and 1 (each within the scatter of the next).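

In this assay, replacing 4-hydroxycyclohexyl with 2-(oxan-4-yl)ethyl on the amide-type nitrogen gives a 3.5-fold lower number from compound 3 to compound 4 (0.54 log units; beyond the scatter), so this change moves the number beyond the scatter even though the opening estimate rested on steps that involved neither group. Compound 4 also stands level with the better of the two stereoisomers, with a 1.4-fold higher number from compound 2 to compound 4 (0.15 log units; within the scatter), while it clearly separates from the other, with a 4.2-fold lower number from compound 1 to compound 4 (0.62 log units; beyond the scatter). A number in this low range at this nitrogen is therefore not tied to a six-membered ring of carbon only or to a defined stereocentre, since compound 4 has neither and its incoming group also carries no hydrogen-bond donor.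

The step from compound 3 to compound 4 changes the ring, the link to the nitrogen and the donor count together, so the compounds shown do not separate these changes, and nothing given here accounts for the lower number. As far as these compounds go, it remains open whether an amine in the ring, as in 2-(piperidin-4-yl)ethyl, or a longer chain ending in the oxane ring would hold this level.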